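The source may report more compounds than this note shows. Statements on the series, on what has been measured and on what is new or still open speak of the compounds shown alone.

The measured compounds:
Compound 1, `O=C(Nc1cccc(C(F)(F)F)c1)N[C@H]1CC[C@H](Oc2ccc(Cl)cc2)CC1`: 2000 nM
Compound 2, `O=C(Nc1cccc(F)c1)N[C@H]1CC[C@H](Oc2ccc(F)cc2)CC1`: 8300 nM

In a functional assay on CRL2813 cells (Homo sapiens) for cytotoxicity, read by sulforhodamine B assay, with a stated time of 5 days (on this read-out lower numbers stand for stronger inhibition and higher numbers for weaker inhibition), compound 2 gives 8300 nM, the highest of the two numbers shown, while compound 1 gives 2000 nM, a difference that lies beyond the usual scatter of repeated measurements. Compound 3, `CSc1ccccc1NC(=O)N[C@H]1CC[C@H](Oc2ccc(F)cc2)CC1`, has not yet been measured. It differs from compound 2 in one place: 2-(methylsulfanyl)phenyl in place of 3-fluorophenyl on an amide-type nitrogen. For the measured compounds named here, no measured pair shows this exact change, so its effect cannot be read directly from the numbers at hand. With compound 1 giving 2000 nM from a different group on the same amide-type nitrogen, a modest step toward a lower number is expected for compound 3, though one that may well fall within the scatter. The expected step is a 1.7-fold lower number from compound 2 to compound 3 (0.22 log units; within the scatter). Compound 3 is expected to give about 5000 nM in this assay, with a likely range from 1500 nM to 15000 nM.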

Compound 3, half-maximal inhibitory concentration: > 20000 nM
Compound 3: only a limit was reported; the forecaster's own chance of this, stated with the estimate: 10%; middle value at least 4.0-fold (0.60 log units) away from the limit.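

In this assay, placing 2-(methylsulfanyl)phenyl instead of 3-fluorophenyl on the amide-type nitrogen gives an at least 2.4-fold higher number from compound 2 to compound 3 (0.38 log units; beyond the scatter), which means weaker inhibition. For the compounds shown here, this is the first direct evidence that a single change of group on this nitrogen, with the rest of the compound held constant, can shift the number by more than the usual scatter, and here the shift is upward. The reading for compound 3 is a limit of the assay and not a number: the limit of > 20000 nM in this assay, at which 1 of the 3 values shown sits.

The compounds shown leave open how far the number really rises, and whether the sulfur-bearing methylsulfanyl group or its place on the ring matters more. They also leave open how a plain phenyl group or a methoxy-substituted phenyl group on the same nitrogen would read.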